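Swapping fluoro for methyl in a rat exposure series

This account rests on a few compounds, and the source may have more. Where it says the series, first, only, none or still open, it means among the compounds named here.

- compound 1 `Cc1cc(C(=O)O)cc(C)c1NC(=O)c1cc(-c2cccc(CO)c2)ccc1F` gives 105 ng.h/mL here
- compound 2 `Cc1cc(C(=O)O)cc(C)c1NC(=O)c1nc(-c2cccc(CO)c2)ccc1C(F)(F)F` gives 243 ng.h/mL here
- compound 3 `Cc1ccc(-c2cccc(CO)c2)cc1C(=O)Nc1c(C)ccc(C(=O)O)c1C` gives 375 ng.h/mL here

These values come from an ADME assay on the whole organism for pharmacokinetics, with Rattus norvegicus as the target, at a dose of 5 mg/kg by the oral route (a higher number here means more compound in the circulation at the dose given, a lower number less compound in the circulation), and compound 1 is the lowest of the three, with both gaps beyond the usual scatter. Compound 4 `Cc1ccc(-c2cccc(CO)c2)cc1C(=O)Nc1c(C)cc(C(=O)O)cc1C` differs from compound 1 by methyl in place of fluoro on an aromatic carbon para to a 3-(hydroxymethyl)phenyl group. Within the data shown here, no measured pair isolates this single change, so the evidence is indirect. Compound 3 also carries methyl in that place and gives 375 ng.h/mL in this test. A rise is therefore expected, estimated as a 2.7-fold higher number from compound 1 to compound 4 (0.43 log units; beyond the scatter) in this assay with real uncertainty. Compound 4 is estimated at 280 ng.h/mL with an expected range from 110 ng.h/mL to 700 ng.h/mL overall.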

Compound 4, area under the concentration-time curve: 88 ng.h/mL
Compound 4: middle estimate off by 3.2-fold (0.50 log units), on the high side; measured number outside the range, below it.
By their numbers in this assay, from the lowest: compounds 4 and 1 (each within the scatter of the next); then compounds 2 and 3 (each within the scatter of the next).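

Putting methyl in place of fluoro on this aromatic carbon, para to a 3-(hydroxymethyl)phenyl group, gives a 1.2-fold lower number from compound 1 to compound 4 (0.08 log units; within the scatter) in this assay. For this pair, the swap alone therefore brings no rise beyond the usual scatter. No measurement shown here explains why the two numbers stay so close.

Going by these compounds, whether a methoxy group or an amine on this same carbon would shift the number remains open. So does whether the same swap would behave alike on a different core.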